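This account rests on a few compounds, and the source may have more. Where it says the series, first, only, none or still open, it means among the compounds named here.

In an ADME assay on HepG2 cells (Homo sapiens) for cytotoxicity, read by MTT assay (a lower number here means a stronger inhibitor, a higher number a weaker inhibitor), compound 1 (`ClC(Cl)(Cl)c1nc(-c2ccccc2)c2ccccc2n1`) reads > 125000 nM as a limit, not a number. Compound 2 (`COc1cc(-c2nc(C(Cl)(Cl)Cl)nc3ccccc23)cc(OC)c1OC`) reads > 125000 nM as a limit too. Compound 3 (`FC(F)(F)c1cccc(-c2nc(C(Cl)(Cl)Cl)nc3ccccc23)c1`) also reads > 125000 nM as a limit. All three therefore sit together, and compound 1 has no exact value (the limit of > 125000 nM in this assay, at which 3 of the 3 values shown sit). Compound 4 (`Cc1ccc(-c2nc(C(Cl)(Cl)Cl)nc3ccccc23)s1`) brings a new change (5-methylthiophen-2-yl in place of phenyl on an aromatic carbon), with 5-methylthiophen-2-yl in place of phenyl on an aromatic carbon. For the measured compounds named here, the only measured step (a step that the two limits leave unreadable from compound 1 to compound 3) cannot be sized, so it offers no size to carry over. In this assay the step expected is none beyond the usual scatter, with no direction favoured (a step that the limit leaves unreadable from compound 1 to compound 4). Compound 4 is estimated at 140000 nM with an expected range of 50000 nM to 300000 nM.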

Compound 4, half-maximal inhibitory concentration: 25000 nM
Estimate against measurement, compound 4: 5.6-fold (0.75 log units) above, and the stated range ends above it.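

In this assay, placing 5-methylthiophen-2-yl instead of phenyl at this position gives an at least 5.0-fold lower number from compound 1 to compound 4 (0.69 log units; beyond the scatter), so a change here can bring the number within the readable range. The step to compound 3 cannot be read, which leaves this as the only change shown with a size. That size is only a minimum, since compound 1 has no exact value: the limit of > 125000 nM in this assay, at which 3 of the 4 values shown sit.

Open, from the compounds shown here alone, is whether the ring or its methyl accounts for the step; thiophen-2-yl without the methyl would separate the two. Also open, going by these compounds, is what an amine or a carboxylic acid at this position would give.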